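A few compounds are considered here, and "the series" means these few. Any claim that something is new, unique, unknown or untested is made for them only; others in the source may bear on it.

Measured in a functional assay on SiHa cells (Homo sapiens) for cytotoxicity, read by MTT assay, with a stated time of 72 h; on this read-out higher numbers stand for an effect only at larger amounts of compound and lower numbers for an effect already at smaller amounts:

- compound 1 `O=C(O)c1cc2ccc(OCc3ccccc3)cc2[nH]c1=O`: > 30000 nM
- compound 2 `CCn1c(=O)c(C(=O)O)cc2ccc(OCc3ccccc3)cc21`: > 30000 nM
- compound 3 `Cc1c(C(=O)O)c(=O)oc2cc(O)ccc12`: > 30000 nM

Each of these entries is a limit of the assay and not a number. Compound 3 therefore stands only at a limit, > 30000 nM, and the series offers no measured number beside it. All the evidence so far sits at one point: the limit of > 30000 nM in this assay, at which 3 of the 3 values shown sit.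

Compound 4 `Cc1c(C(=O)O)c(=O)oc2cc(OCc3ccccc3)ccc12` differs from compound 3 in one place: benzyl in place of hydrogen on an oxygen on an aromatic ring.

Among the compounds with values here, the one measured step, a step that the two limits leave unreadable from compound 1 to compound 2, has no readable size and is a different change, so it gives no measure for this one. More relevant are the two compounds that already carry benzyl on an oxygen on an aromatic ring. Compound 1 gives the limit > 30000 nM. Compound 2 also gives a limit, > 30000 nM.

With these two compounds as the guide, no gain in this assay is expected, and the assay may well report only a limit again. The estimated change, a number no higher from compound 3 to compound 4 (the limit leaves the size open), is expected to stay within the usual scatter, in neither direction. Compound 4 is estimated at 30000 nM, with an expected range from 15000 nM to 60000 nM.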

Compound 4, half-maximal effective concentration: > 30000 nM
Compound 4: only a limit was reported; the forecaster's own chance of this, stated with the estimate: 75%; the middle value lies on the limit itself.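

In this assay compound 4 gives > 30000 nM, which is a limit of the assay and not a number. Within the data shown here, compound 3 also stands only at a limit, so no step from compound 3 to compound 4 can be read. The compounds shown leave open whether any change to these structures would give a measurable number in this assay, and all the evidence sits at one point: the limit of > 30000 nM in this assay, at which 4 of the 4 values shown sit.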